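Swapping an Open-Chain Amine for a Ring on Sulfur

This account rests on a few compounds, and the source may have more. Where it says the series, first, only, none or still open, it means among the compounds named here.

Two compounds share a core that carries an acid-bearing chain and a sulfonyl group. Compound 1 `COCCN(C)S(=O)(=O)c1ccc(C)c(C#Cc2cc(Cl)ccc2OCC(=O)O)c1` was tested in an assay on CHO cells for displacement of a labelled ligand from prostaglandin D2 receptor 2 (Homo sapiens), read by scintillation counting (a lower number here means a stronger inhibitor, a higher number a weaker inhibitor), and gives 4.1 nM. Going by the values given here, compound 2 `COC1(C)c2ccc(C#Cc3cc(Cl)ccc3OCC(=O)O)cc2S(=O)(=O)C1(C)C` gives 25 nM in this assay, so compound 1 stands with the lower of the two numbers measured so far, and its gap to compound 2 lies beyond the usual scatter.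

Compound 3 `Cc1ccc(S(=O)(=O)N2CCCCC2C)cc1C#Cc1cc(Cl)ccc1OCC(=O)O` has not yet been measured. It differs from compound 1 in one place: 2-methylpiperidin-1-yl in place of (2-methoxyethyl)(methyl)amino on a sulfonyl sulfur. The group that leaves has no ring and one hydrogen-bond acceptor; the group that enters is one six-membered non-aromatic ring with one hetero atom and no hydrogen-bond acceptors, on the same sulfonyl sulfur.

Among the compounds with values here, no pair of measured compounds shows the effect of such a change, so the expectation rests on how little else is altered. The step from compound 1 to compound 3 is expected to be small, a 1.5-fold higher number from compound 1 to compound 3 (0.17 log units; within the scatter), likely within the scatter or leaning toward a higher number. Compound 3 is therefore estimated at 6 nM, within a range of 2 nM to 20 nM.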

Compound 3, inhibition constant: 1.9 nM
Beside the measured number, compound 3's estimate is 3.2-fold (0.50 log units) above it, and the stated range ends above it.
By their numbers in this assay, from the lowest: compound 3; then compound 1; then compound 2.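

In this assay, the sulfonyl sulfur of this series accepts a closed ring in place of an open chain: the change to 2-methylpiperidin-1-yl gives a 2.2-fold lower number from compound 1 to compound 3 (0.33 log units; beyond the scatter) and so brings a modest gain rather than a loss. Going by these compounds alone, the hydrogen-bond acceptor counted in (2-methoxyethyl)(methyl)amino is therefore not needed for a low number at this position, at least on the core of compound 1, something the earlier compounds could not show, since no single change linked them. Nothing available accounts for the direction of this step, so it stands as an observation about this one pair and not as an explanation.

The change removes the acceptor, closes a ring and brings in a methyl group on that ring all at once, so the compounds shown leave open which of these differences carries the step. Plain piperidin-1-yl would bear on the part played by the methyl group, while morpholin-4-yl, a six-membered ring that keeps an oxygen atom, would bear on whether the ring and an acceptor can sit together on this sulfur.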